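Swapping an amide for ethyl on two inactive cores

A few compounds are considered here, and "the series" means these few. Any claim that something is new, unique, unknown or untested is made for them only; others in the source may bear on it.

The read-out throughout is a functional assay on HeLa cells (Homo sapiens) for antiproliferative activity, read by MTT assay, with a stated time of 48 h; on this read-out lower numbers stand for stronger inhibition and higher numbers for weaker inhibition. Compound 1 `Cn1cc(-c2cnc3ccc(NC(=O)c4cccnc4)nc3c2)cn1` carries a (pyridin-3-yl)carbonyl group on a nitrogen on an aromatic ring. In this assay compound 1 gives > 50000 nM, which is a limit of the assay and not a number. Compound 2 `CCNc1ccc2ncc(-c3cnn(C)c3)cc2n1` has the change (ethyl in place of (pyridin-3-yl)carbonyl on a nitrogen on an aromatic ring). In this assay compound 2 gives > 50000 nM, again a limit rather than a number. The resulting step is a step that the two limits leave unreadable from compound 1 to compound 2.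

Compound 3 `Cn1cc(-c2cnc3ccnc(NC(=O)c4cccnc4)c3c2)cn1` has the same atoms as compound 1, joined differently; the difference between the two cores is not broken down here. In this assay compound 3 gives > 50000 nM, once more a limit and not a number. Within the data shown here, compound 4 `CCNc1nccc2ncc(-c3cnn(C)c3)cc12` has not been measured; it differs from compound 3 by ethyl in place of (pyridin-3-yl)carbonyl on a nitrogen on an aromatic ring, the same change as the one from compound 1 to compound 2, at a place described in the same words.

Among the measured compounds shown here, the only evidence on offer is the limit of > 50000 nM in this assay, at which 3 of the 3 values shown sit. Because the limit of > 50000 nM in this assay, at which 3 of the 3 values shown sit, contains every measured value, the earlier step cannot be read, and the new one is expected to be equally unreadable. For compound 4 the expected step is a step that the limit leaves unreadable from compound 3 to compound 4, estimated to fall at the limit. Compound 4 is expected to give 60000 nM in this assay, with a range from 20000 nM to 200000 nM, and most likely only a limit will be reported.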

Compound 4, half-maximal inhibitory concentration: > 50000 nM
Compound 4: no number, only a limit; the forecaster's own chance of this, stated with the estimate: 85%; the middle value does not contradict the limit.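

Among these compounds, neither the step from compound 3 to compound 4 nor the one from compound 1 to compound 2 can be read; all four compounds stop at the same limit of the assay, which is not a number: the limit of > 50000 nM in this assay, at which 4 of the 4 values shown sit. The compounds shown leave open whether ethyl and (pyridin-3-yl)carbonyl differ at all in their effect on either core, and how the two cores compare.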